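Replacing a benzimidazole arm with a pyrrolidine chain

The compounds below may be only part of what the source reports. "The series", "measured", "known", "first", "only" and "open" are said of these compounds alone.

Compounds measured in a functional assay on A549 cells (Homo sapiens) for cytotoxicity, read by MTT assay, with a stated time of 48 h (on this read-out higher numbers stand for weaker inhibition and lower numbers for stronger inhibition), so far:
compound 1 `CCCCNCCOc1c(O)cc(O)c2c(=O)cc(-c3ccccc3)oc12`, no result ("not determined" (no result reported))
compound 2 `COc1c(OCc2nc3ccccc3[nH]2)cc(O)c2c(=O)cc(-c3ccccc3)oc12`, a limit of the assay (> 100000 nM)
compound 3 `CCCCNCCCCOc1c(O)cc(O)c2c(=O)cc(-c3ccccc3)oc12`, no result ("not determined" (no result reported))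

Compound 2 gives > 100000 nM as a limit of the assay and not a number. Going by the values given here, it is the only one of the three compounds with any reading, and no measured pair offers a step to go by.

Compound 4 `COc1c(OCCCCN2CCCC2)cc(O)c2c(=O)cc(-c3ccccc3)oc12` is still unmeasured. It keeps the core of compound 2 and differs in one group (3-(pyrrolidin-1-yl)propyl in place of 1H-benzimidazol-2-yl on a saturated chain carbon bound to an oxygen on an aromatic ring): 3-(pyrrolidin-1-yl)propyl in place of 1H-benzimidazol-2-yl on a saturated chain carbon bound to an oxygen on an aromatic ring. Cut one bond further out, the change reads (1H-benzimidazol-2-yl)methyl to 4-(pyrrolidin-1-yl)butyl.

With compound 2 at its limit (> 100000 nM), any number for compound 4 would mean stronger inhibition in this assay, although another limit reading remains possible. A modest step is expected, an at least 3.3-fold lower number from compound 2 to compound 4 (0.52 log units; beyond the scatter) toward stronger inhibition. The estimate for compound 4 is 30000 nM (expected range 8000 nM to 100000 nM).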

Compound 4, half-maximal inhibitory concentration: 1530 nM
Beside the measured number, compound 4's estimate is 20-fold (1.29 log units) above it; measured number below the stated range.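

In this assay, the group carried at this position on the shared core proves able to move the read-out: 3-(pyrrolidin-1-yl)propyl in place of 1H-benzimidazol-2-yl, on a saturated chain carbon bound to an oxygen on an aromatic ring, gives an at least 65-fold lower number from compound 2 to compound 4 (1.81 log units; beyond the scatter). Going by these compounds alone, compound 4 thus supplies the first actual number in this set, where the earlier compounds offered only a limit or no result. The step can be read only as a minimum because one of its ends is a limit: the limit of > 100000 nM in this assay, at which 1 of the 4 values shown sits.

In this change, (1H-benzimidazol-2-yl)methyl gives way to 4-(pyrrolidin-1-yl)butyl, so the ring and the chain differ together, and the compounds shown cannot separate the two. On these data alone, whether a piperidine or morpholine on the same chain, or the pyrrolidine on a shorter chain, would give a similar reading remains open.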